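Hydroxy to Amino on the Amide Chain, Two Cores

The source may report more compounds than this note shows. Statements on the series, on what has been measured and on what is new or still open speak of the compounds shown alone.

Measured compounds in a functional assay on MCF7 cells (Homo sapiens) for antiproliferative activity, read by MTT assay, with a stated time of 48 h; on this read-out lower numbers stand for stronger inhibition and higher numbers for weaker inhibition:
compound 1, `COc1ccc(C(=O)c2ccc3c(c2)C=CC(C)(C)O3)c(NC(=O)CO)c1`, gives 200 nM.
compound 2, `COc1ccc(C(=O)c2ccc3c(c2)C=CC(C)(C)O3)c(NC(=O)CN)c1`, gives 680 nM.
compound 3, `C=C(c1ccc(OC)cc1NC(=O)CO)c1ccc(OC)c2c1OC(C)(C)C=C2`, gives 100 nM.

Compound 2 differs from compound 1 by amino in place of hydroxy on a saturated chain carbon bound to a carbonyl carbon; this change reads as a 3.4-fold higher number from compound 1 to compound 2 (0.53 log units; beyond the scatter). Compound 3 carries the same side chain as compound 1 on another core; the difference between the two cores is not broken down here. In this assay compound 3 and compound 1 lie within the scatter of each other, while compound 2 stands beyond both.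

Compound 4, `C=C(c1ccc(OC)cc1NC(=O)CN)c1ccc(OC)c2c1OC(C)(C)C=C2`, is not yet measured. It differs from compound 3 by amino in place of hydroxy on a saturated chain carbon bound to a carbonyl carbon, the same change as from compound 1 to compound 2. The step is expected to read a 3.4-fold higher number from compound 3 to compound 4 (0.53 log units; beyond the scatter), because the same change on the core of compound 1 gave a 3.4-fold higher number from compound 1 to compound 2 (0.53 log units; beyond the scatter). Compound 4 is therefore estimated at 340 nM, expected between 150 nM and 800 nM.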

Compound 4, half-maximal inhibitory concentration: 220 nM
Compound 4: the middle estimate sits 1.5-fold (0.19 log units) above what was measured; the measured number falls inside the stated range.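

On the second core, amino in place of hydroxy again gives a higher number in this assay with a 2.2-fold higher number from compound 3 to compound 4 (0.34 log units; beyond the scatter) as the new step, and the two steps do not differ beyond the scatter: the same change on two cores in this assay, a 3.4-fold higher number (0.53 log units; beyond the scatter) from compound 1 to compound 2 and a 2.2-fold higher number (0.34 log units; beyond the scatter) from compound 3 to compound 4, 1.5-fold (0.19 log units) apart, within the scatter of two such steps

Across these two cores the change therefore carries over in direction and, within the scatter, in size. Two cores are only two cases, so this gives no rule for other cores in the series, and the numbers do not show what lies behind the step.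

The compounds shown leave open how a dimethylamino group, a carboxylic acid or a longer chain ending in an amine would read at this place in this assay on either core. They also leave open whether the step holds in any other cell line.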